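The compounds below may be only part of what the source reports. "The series", "measured", "known", "first", "only" and "open" are said of these compounds alone.

Measured compounds in an ADME assay on MDBK cells (Bos taurus) for cytotoxicity, read by MTT assay, with a stated time of 96 h; a lower number here means that less compound is tolerated, a higher number that more compound is tolerated:
compound 1 `C/C(=N\NC(N)=O)c1ccc2[nH]c(-c3ccc(C(F)(F)F)cc3)nc2c1`: > 100000 nM, a limit of the assay.
compound 2 `COc1ccc(-c2nc3cc(/C(C)=N/NC(N)=O)ccc3[nH]2)cc1`: 25000 nM.
compound 3 `C/C(=N\NC(N)=S)c1ccc2c(c1)nc(-c1ccc(C(F)(F)F)cc1)n2C1CCCCC1`: > 100000 nM, a limit of the assay.

For the measured compounds named here, the only measured step, an at least 4.0-fold lower number from compound 1 to compound 2 (0.60 log units; beyond the scatter), is the change (methoxy in place of trifluoromethyl on an aromatic carbon). Compound 4 `COc1ccc(-c2nc3cc(/C(C)=N/NC(N)=S)ccc3n2C2CCCCC2)cc1` carries the same change relative to compound 3, (methoxy in place of trifluoromethyl on an aromatic carbon). The difference between the core of compound 1 and the core of compound 3 is not broken down here. Compound 1 and compound 3 both sit at the limit of > 100000 nM in this assay, at which 2 of the 3 values shown sit, so the measured step is itself only a bound, and the starting point of compound 3 in this assay is likewise only a bound. The step from compound 3 to compound 4 is expected to be of similar size, an at least 2.5-fold lower number from compound 3 to compound 4 (0.39 log units; beyond the scatter), resting on compound 1 and compound 2 through an at least 4.0-fold lower number from compound 1 to compound 2 (0.60 log units; beyond the scatter). Compound 4 is therefore expected near 40000 nM in this assay, estimated between 15000 nM and 150000 nM.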

Compound 4, half-maximal cytotoxic concentration: 32000 nM
The estimate for compound 4 lay 1.3-fold (0.10 log units) above the measured number; the measured number falls inside the stated range.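

Methoxy in place of trifluoromethyl on an aromatic carbon gives, in this assay, an at least 3.1-fold lower number from compound 3 to compound 4 (0.49 log units; beyond the scatter). The lower number therefore appears on both cores, the two steps set side by side reading: the same change on two cores in this assay, an at least 4.0-fold lower number (0.60 log units; beyond the scatter) from compound 1 to compound 2 and an at least 3.1-fold lower number (0.49 log units; beyond the scatter) from compound 3 to compound 4; the limit leaves it open whether they differ. The exact size of neither step is known and equal size across the cores is not shown, with compound 1 and compound 3 each standing only at a limit: the limit of > 100000 nM in this assay, at which 2 of the 4 values shown sit.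

Open, going by these compounds, is how an amine, a carboxylic acid or a longer chain such as butoxy would read in the same place in this assay. Also open, on these data alone, is whether the lower number with methoxy extends to any core beyond these two.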